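The source may report more compounds than this note shows. Statements on the series, on what has been measured and on what is new or still open speak of the compounds shown alone.

Within the data shown here, in an ADME assay on the whole organism (strain FVB) for pharmacokinetics, with Mus musculus as the target, read by LC-MS, at a dose of 30 mg/kg by the oral route (a higher number here means more compound in the circulation at the dose given, a lower number less compound in the circulation), compound 1 `CC(C)(N)CCOc1ccc([C@H]2CC[C@]3(CC2)OOC2(O3)C3CC4CC(C3)CC2C4)cc1` gives 12300 ng.h/mL and compound 2 `N[C@H]1CC[C@@H](Oc2ccc([C@H]3CC[C@]4(CC3)OOC3(O4)C4CC5CC(C4)CC3C5)cc2)CC1` gives 13400 ng.h/mL, so compound 2 stands within the usual scatter of the only other measured compound. Compound 3 `CC1(C)CC(O)(COc2ccc([C@H]3CC[C@]4(CC3)OOC3(O4)C4CC5CC(C4)CC3C5)cc2)CC(C)(C)N1` has (4-hydroxy-2,2,6,6-tetramethylpiperidin-4-yl)methyl in place of 4-aminocyclohexyl on an oxygen on an aromatic ring. Among the measured compounds shown here, the one measured step that changes the group on this oxygen, a 1.1-fold higher number from compound 1 to compound 2 (0.04 log units; within the scatter), is small. It is thin evidence for a much larger group, but no change beyond the scatter is expected. The expected step is a 1.3-fold lower number from compound 2 to compound 3 (0.13 log units; within the scatter). Compound 3 is estimated at 10000 ng.h/mL, with an expected range of 3500 ng.h/mL to 28000 ng.h/mL.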

Compound 3, area under the concentration-time curve: 17300 ng.h/mL
Beside the measured number, compound 3's estimate is 1.7-fold (0.24 log units) below it; the range from low to high includes it.
By their numbers in this assay, from the lowest: compounds 1, 2 and 3 (each within the scatter of the next).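

In this assay, the group on this oxygen can go from 4-aminocyclohexyl to the larger (4-hydroxy-2,2,6,6-tetramethylpiperidin-4-yl)methyl with only a small step (a 1.3-fold higher number from compound 2 to compound 3 (0.11 log units; within the scatter)). Putting 4-hydroxy-2,2,6,6-tetramethylpiperidin-4-yl in place of 2-amino-2-methylpropyl on the saturated chain carbon also gives a small step (a 1.4-fold higher number from compound 1 to compound 3 (0.15 log units; within the scatter)), so all three groups lie within the scatter of one another. Nothing measured here accounts for this flat result. Every group shown carries an amine, so it remains open whether a carboxylic acid or a plain alkyl chain on this oxygen would give a similar number.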